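The compounds below may be only part of what the source reports. "The series", "measured", "known", "first", "only" and "open" are said of these compounds alone.

Working notes on the shared core of this series, read in an ADME assay for pharmacokinetics, read by LC-MS, in phosphate buffer, with a stated time of 120 min, at pH 7.4, tested at 1 uM, in the presence of a further agent that is not named here; on this read-out higher numbers stand for a longer-lived compound and lower numbers for a shorter-lived compound. Compound 1 `C=C(Cc1ccccc1)C(=O)Nc1ccccc1` returns only an assay limit: in this assay compound 1 gives > 8.53 h. Compound 2 `C=C(CCO)C(=O)Nc1ccccc1`, which carries hydroxymethyl in place of phenyl on a saturated chain carbon bound to a double-bonded chain carbon, likewise sits at a limit, and in this assay compound 2 gives > 8.53 h. The step that the two limits leave unreadable from compound 1 to compound 2 cannot be read, since the limit of > 8.53 h in this assay, at which 2 of the 3 values shown sit, holds both values. Going by the values given here, compound 3 `CN(C)CC/C=C/C(=O)Nc1ccccc1` is the only member with a number: in this assay compound 3 gives 7.38 h. Compound 2 therefore stands among the two values that sit at the limit, and no readable measured step reaches it from any other compound.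

Compound 4 `C=C(F)C(=O)Nc1ccccc1` differs from compound 2 by fluoro in place of 2-hydroxyethyl on a double-bonded chain carbon bound to a carbonyl carbon. Among the compounds with values here, no measured step alters a group on a double-bonded chain carbon bound to a carbonyl carbon, and none brings in fluoro, so the measured steps offer no direct guide; the only readable information is the single number from compound 3. For compound 4 a shorter half-life than the limit of compound 2 is expected, with the step of an at least 2.8-fold lower number from compound 2 to compound 4 (0.45 log units; beyond the scatter) expected to lie beyond the scatter. The half-life of compound 4 in this assay is estimated at 3 h, within a range from 0.8 h to 8.53 h.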

Compound 4, half-life: > 8.53 h
Compound 4: no number, only a limit; the forecaster's own chance of this, stated with the estimate: 25%; middle value at least 2.8-fold (0.45 log units) from the limit.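

No new step can be read between compound 2 and compound 4, since each returns only an assay limit and not a number: the limit of > 8.53 h in this assay, at which 3 of the 4 values shown sit.

The compounds shown leave open whether fluoro in place of 2-hydroxyethyl on a double-bonded chain carbon bound to a carbonyl carbon changes the half-life in this assay at all.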